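This account rests on a few compounds, and the source may have more. Where it says the series, first, only, none or still open, it means among the compounds named here.

Compound 1 `Cc1nc(S(C)(=O)=O)ccc1Oc1ncnc(OC2CCN(C(=O)OC(C)(C)C(F)(F)F)CC2)c1F` gives 79% in a functional assay on isolated protein for inhibition of Glucose-dependent insulinotropic receptor (Rattus norvegicus), read by HTRF and cAMP accumulation; on this read-out higher numbers stand for larger maximal responses and lower numbers for smaller maximal responses. Compound 2 `Cc1nc(S(C)(=O)=O)ccc1Oc1ncnc(OC2CCN(C(=O)O[C@H](C)C(F)(F)F)CC2)c1F` gives 85% in this assay. Compound 3 `Cc1nc(S(C)(=O)=O)ccc1Oc1ncnc(OC2CCN(C(=O)c3noc(C(C)(C)F)n3)CC2)c1F` gives 74% in this assay.

Compound 3 stands lowest of the three numbers, but not clearly apart: the comparison runs a number 5 percentage points lower from compound 1 to compound 3 (within the scatter) and a number 11 percentage points lower from compound 2 to compound 3 (beyond the scatter). Compound 4 `Cc1nc(S(C)(=O)=O)ccc1Oc1ncnc(OC2CCN(C(=O)c3nc(C(C)(C)F)no3)CC2)c1F` is its rearranged partner: a group of 9 heavy atoms (5 carbon, 2 nitrogen, 1 oxygen, 1 fluorine; one five-membered aromatic ring with 3 hetero atoms) in place of a group of 9 heavy atoms (5 carbon, 2 nitrogen, 1 oxygen, 1 fluorine; one five-membered aromatic ring with 3 hetero atoms), on a carbonyl carbon. Within the data shown here, no measured step alters the group on the carbonyl carbon in this way; the two steps that touch that position, a number 5 percentage points lower from compound 1 to compound 3 (within the scatter) and a number 11 percentage points lower from compound 2 to compound 3 (beyond the scatter), exchange the ring for a chain and are small or modest. Compound 4 is therefore expected to sit close to compound 3, with a number 1 percentage points higher from compound 3 to compound 4 (within the scatter) as the likely step, not beyond the scatter. The estimate for compound 4 is 75%, in the range 65% to 85%.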

Compound 4, largest response reached (reported as efficacy), in percent of the reference or control that the assay uses: 84%
Beside the measured number, compound 4's estimate is 9 percentage points below it, and the stated range covers the measured number.
By their numbers in this assay, from the lowest: compounds 3, 1, 4 and 2 (each within the scatter of the next, the first and the last beyond it).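

In this assay, joining the same atoms differently in the five-membered aromatic ring on the carbonyl carbon gives a number 10 percentage points higher from compound 3 to compound 4 (within the scatter), so this rearrangement does not move the number past the scatter. The ring in compound 4 also stays within the scatter of both chains, with a number 1 percentage points lower from compound 2 to compound 4 (within the scatter) and a number 5 percentage points higher from compound 1 to compound 4 (within the scatter). Nothing available explains these numbers.

The compounds shown leave open how a ring without fluorine, or an open-chain amine on the same carbonyl carbon, would read out.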